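The source may hold more compounds than are shown below. What is called first, only, known or untested is meant among the compounds shown, and "the series" means these compounds.

In an ADME assay on cells (Hepatocyte, Homo sapiens) for metabolic stability (on this read-out lower numbers stand for a shorter-lived compound and higher numbers for a longer-lived compound), compound 2 `Cc1nnc(N2CCC(C(=O)N3N=CC[C@H]3c3ccccc3)CC2)o1` gives 3.3 h. Compound 3 `Cc1nnc(N2CCC(C(=O)N3N=CC[C@H]3c3cc(F)cc(F)c3)CC2)o1` gives 3.3 h, level with compound 2 at the digits shown. Compound 1 `O=C(C1CCN(c2ncccn2)CC1)N1N=CC[C@H]1c1ccccc1` gives > 3.11 h, which is a limit of the assay and not a number.

The next structure is compound 4 `O=C(C1CCN(c2ccccn2)CC1)N1N=CC[C@H]1c1ccccc1`, and the change from compound 2 is this: pyridin-2-yl in place of 5-methyl-1,3,4-oxadiazol-2-yl on an amine nitrogen in a ring. The exchange falls on an amine nitrogen in a ring. Among the compounds with values here, the only measured step at that place is a step that the limit leaves unreadable from compound 1 to compound 2, and it gives neither a size nor a direction. The other measured step, no change at the digits printed from compound 2 to compound 3 (within the scatter), lies on a saturated ring carbon and stays within the scatter, so it bears only weakly on this exchange.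

With no readable precedent for a direction, no move beyond the scatter is expected in this assay, and the expected step is a 1.1-fold lower number from compound 2 to compound 4 (0.06 log units; within the scatter). The estimated half-life of compound 4 is 2.9 h, with an expected range of 1.4 h to 5.5 h.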

Compound 4, half-life: > 3.11 h
Compound 4: no number, only a limit; the forecaster's own chance of this, stated with the estimate: 30%; middle value at least 1.0-fold (0.03 log units) away from the limit.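

In this assay compound 4 gives > 3.11 h, a limit of the assay and not a number. Within the data shown here, no step from compound 1 or compound 2 to compound 4 can be read. Still open is whether pyridin-2-yl, pyrimidin-2-yl and 5-methyl-1,3,4-oxadiazol-2-yl on the amine nitrogen differ at all, given this shared ceiling: the limit of > 3.11 h in this assay, at which 2 of the 4 values shown sit.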